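An ester extended by methoxy, and what to expect

This account rests on a few compounds, and the source may have more. Where it says the series, first, only, none or still open, it means among the compounds named here.

In a physicochemical assay for solubility, at pH 7.4 (a lower number here means a less soluble compound, a higher number a more soluble compound), compound 3 (`CC(=O)OCCCS(=O)(=O)c1ccc(S(N)(=O)=O)s1`) gives 920 ug/mL as its reading. That is level with compound 1 (`CC(=O)OCCS(=O)(=O)c1ccc(S(N)(=O)=O)s1`) at 880 ug/mL on the same scale, while compound 2 (`NS(=O)(=O)c1ccc(S(=O)(=O)CCCO)s1`), which carries no acetyl, reaches 14600 ug/mL and stands well clear of both. Compound 4 (`COCC(=O)OCCCS(=O)(=O)c1ccc(S(N)(=O)=O)s1`) keeps the ester of compound 3 and has methoxy in place of hydrogen on a saturated chain carbon bound to a carbonyl carbon.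

The two large steps, a 17-fold higher number from compound 1 to compound 2 (1.22 log units; beyond the scatter) and a 16-fold lower number from compound 2 to compound 3 (1.20 log units; beyond the scatter) in the data, each separate an ester from a free hydroxyl compound, and compound 4 remains an ester. The closer precedent is acetoxymethyl in place of acetoxy, which gave a 1.0-fold higher number from compound 1 to compound 3 (0.02 log units; within the scatter) and stays within the scatter. No step beyond the scatter is therefore expected in this assay here, with at most a slight upward lean. The expected change is a 1.4-fold higher number from compound 3 to compound 4 (0.15 log units; within the scatter) on this reasoning. For compound 4 the estimated reading is 1300 ug/mL with an expected range of 600 ug/mL to 3000 ug/mL in this measurement.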

Compound 4, solubility: 970 ug/mL
Beside the measured number, compound 4's estimate is 1.3-fold (0.13 log units) above it; the range from low to high includes it.
By their numbers in this assay, from the lowest: compounds 1, 3 and 4 (each within the scatter of the next); then compound 2.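

In this assay methoxy in place of hydrogen on a saturated chain carbon bound to a carbonyl carbon gives a 1.1-fold higher number from compound 3 to compound 4 (0.02 log units; within the scatter) and thus shows that the acetyl part of the ester, unchanged in the earlier esters, can carry this group with no step beyond the scatter. Replacing the hydrogen on the oxygen with (methoxymethyl)carbonyl still gives a large step, a 15-fold lower number from compound 2 to compound 4 (1.18 log units; beyond the scatter) as it is read here, while a 1.1-fold higher number from compound 1 to compound 4 (0.04 log units; within the scatter) places this ester within the scatter of the shorter-chain ester. Nothing measured here explains these readings.

Going by these compounds, whether an amine or a carboxylic acid at this saturated chain carbon would stay within the scatter as methoxy does remains open. So does the outcome for a longer chain ending in methoxy at the same place.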